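A few compounds are considered here, and "the series" means these few. Any claim that something is new, unique, unknown or untested is made for them only; others in the source may bear on it.

Measured in a functional assay on B16-F1 cells (Mus musculus) for antiproliferative activity, read by MTT assay, with a stated time of 72 h; on this read-out higher numbers stand for weaker inhibition and lower numbers for stronger inhibition:
- compound 1 `C/C=C1/[C@H](O[C@@H]2O[C@H](CO)[C@@H](O)[C@H](O)[C@H]2O)OC=C(C(=O)OC)[C@H]1CC(=O)OCCCCCCCCCCCCCCC` gives 1500 nM
- compound 2 `C/C=C1/[C@H](O[C@@H]2O[C@H](COC(C)=O)[C@@H](OC(C)=O)[C@H](OC(C)=O)[C@H]2OC(C)=O)OC=C(C(=O)OC)[C@H]1CC(=O)OCCCCCCCCCCCCCCC` gives 34100 nM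
- compound 3 `C/C=C1/[C@H](O[C@@H]2O[C@H](CO)[C@@H](O)[C@H](O)[C@H]2O)OC=C(C(=O)OC)[C@H]1CC(=O)OCCC1CCCCC1` gives 5040 nM

Compound 3 sits in the middle of these three numbers, and its gaps to the other two lie beyond the scatter. Its value is higher than that of compound 1 (1500 nM) and lower than that of compound 2 (34100 nM).

The next compound, compound 4 `C/C=C1/[C@H](O[C@@H]2O[C@H](CO)[C@@H](O)[C@H](O)[C@H]2O)OC=C(C(=O)OC)[C@H]1CC(=O)OCCc1ccc(O)c(O)c1`, keeps the shared core of compound 3 but places 3,4-dihydroxyphenyl in place of cyclohexyl on a saturated chain carbon, two bonds along the chain from an oxygen next to a carbonyl group.

For the measured compounds named here, no measured pair tests this kind of swap, so any forecast is uncertain. Compound 3 (5040 nM) is the only starting point, and its cyclohexyl group contains only carbon, unlike the incoming group. A large step toward a higher number, beyond the scatter, is expected in this assay, and it is estimated as a 16-fold higher number from compound 3 to compound 4 (1.20 log units; beyond the scatter) here.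

For compound 4 the estimated value is 80000 nM, with an expected range from 15000 nM to 300000 nM in this estimate.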

Compound 4, half-maximal inhibitory concentration: 284000 nM
Compound 4: the middle estimate sits 3.6-fold (0.55 log units) below what was measured; the measured number falls inside the stated range.
By their numbers in this assay, from the lowest: compound 1; then compound 3; then compound 2; then compound 4.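

Replacing cyclohexyl with 3,4-dihydroxyphenyl on a saturated chain carbon, two bonds along the chain from an oxygen next to a carbonyl group, gives in this assay a 56-fold higher number from compound 3 to compound 4 (1.75 log units; beyond the scatter) and shows that the outcome in this assay depends strongly on the group held at this place. This single swap changes several things at once: the ring goes from non-aromatic to aromatic, and two oxygens enter, adding two hydrogen-bond donors and two hydrogen-bond acceptors, so the step cannot be assigned to any one of these changes. No measurement at hand explains why the number rises so far.

The compounds shown leave open whether the aromatic ring or its two hydroxyl groups account for the step, a question that plain phenyl or 4-hydroxyphenyl at this place could help separate. They also leave open how an amine or a carboxylic acid would behave at this same chain carbon.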